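Swapping a Chain-End Alcohol for a Ketone

This account rests on a few compounds, and the source may have more. Where it says the series, first, only, none or still open, it means among the compounds named here.

Compound 3 `C=CCc1cc(C(C)=O)c(O)cc1OCCCCCC(C)(C)O` belongs to a set of three close relatives that share one core and differ only at the end of a chain. In an assay on isolated protein for binding affinity to leukotriene B4 receptor 1 (Homo sapiens), tested at 1 uM (a lower number here means less inhibition, a higher number more inhibition at the concentration tested (going by the name of the read-out)), compound 3 gives 60%, the second highest of the three numbers. Compound 1 `C=CCc1cc(C(C)=O)c(O)cc1OCCCCCCC#N` gives 63%, and compound 2 `C=CCc1cc(C(C)=O)c(O)cc1OCCCC` gives 8%. The steps show what matters: a number 55 percentage points lower from compound 1 to compound 2 (beyond the scatter) and a number 52 percentage points higher from compound 2 to compound 3 (beyond the scatter) are both large, while a number 3 percentage points lower from compound 1 to compound 3 (within the scatter) is not. Compound 4 `C=CCc1cc(C(C)=O)c(O)cc1OCCCCCC(C)=O` differs from compound 3 by acetyl in place of 1-hydroxy-1-methylethyl on a saturated chain carbon, five bonds along the chain from an oxygen on an aromatic ring. Because a number 3 percentage points lower from compound 1 to compound 3 (within the scatter) shows that exchanging one chain-end group for another left the number nearly unchanged, the step of a number 2 percentage points lower from compound 3 to compound 4 (within the scatter) is expected to stay within the scatter. Compound 4 is therefore estimated at 58%, with a range from 40% to 75%.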

Compound 4, a percentage reported as inhibition, at one concentration (the size of the read-out at that concentration, not a potency): 58%
The estimate for compound 4 equals the measured number at the digits printed, within the range that was stated.
By their numbers in this assay, from the lowest: compound 2; then compounds 4, 3 and 1 (each within the scatter of the next).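

At this chain end, acetyl in place of 1-hydroxy-1-methylethyl takes away the hydrogen-bond donor, yet this assay records a number 2 percentage points lower from compound 3 to compound 4 (within the scatter) for the swap. The ketone also stands level with the nitrile, with a number 5 percentage points lower from compound 1 to compound 4 (within the scatter) on that comparison, and it keeps the large gain over the short butyl chain, with a number 50 percentage points higher from compound 2 to compound 4 (beyond the scatter) in this assay. Compound 4 is thus a second compound, after compound 1, that keeps the number without a donor on its chain end.

From the compounds shown here alone, whether a carboxylic acid or an amine at this chain end would hold the number stays open. Nothing measured here bears on why these end groups behave alike.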